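From benzoyl to cyclopropylcarbonyl at the assay limit

The source may report more compounds than this note shows. Statements on the series, on what has been measured and on what is new or still open speak of the compounds shown alone.

Compound 3 (`COc1ccc(-n2c(SCC(=O)c3ccccc3)nnc2-c2cc(OC)c(OC)c(OC)c2)cc1`) carries a benzoyl group on a saturated chain carbon bound to a sulfur. In a functional assay on HCT-116 cells (Homo sapiens) for inhibition, read by MTT assay, with a stated time of 48 h (a higher number here means a weaker inhibitor, a lower number a stronger inhibitor), compound 3 gives > 60000 nM as a limit of the assay, not a number. Compound 1 (`COc1ccc(-n2c(SC)nnc2-c2cc(OC)c(OC)c(OC)c2)cc1`) gives > 60000 nM as a limit too. Compound 2 (`COc1ccc(CSc2nnc(-c3cc(OC)c(OC)c(OC)c3)n2-c2ccc(OC)cc2)cc1`), with 4-methoxyphenyl in place of that benzoyl, gives 49600 nM as an actual number.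

Compound 4 (`COc1ccc(-n2c(SCC(=O)C3CC3)nnc2-c2cc(OC)c(OC)c(OC)c2)cc1`) has cyclopropyl in place of phenyl on a carbonyl carbon, turning benzoyl into cyclopropylcarbonyl. Among the measured compounds shown here, no measured step makes this exact swap. The nearest evidence comes from changes at the same chain carbon. One is an at least 1.2-fold higher number from compound 2 to compound 3 (0.08 log units; that floor lies within the scatter) and another is a step that the two limits leave unreadable from compound 1 to compound 3, while an at least 1.2-fold lower number from compound 1 to compound 2 (0.08 log units; that floor lies within the scatter) completes the set. None of these shows a readable change beyond the scatter, and the series sits largely at the limit of > 60000 nM in this assay, at which 2 of the 3 values shown sit, in this family.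

No step beyond the scatter is therefore expected in this assay for this swap. The estimated step is a number no higher from compound 3 to compound 4 (the limit leaves the size open) and it may well be hidden behind a limit. The expected value for compound 4 is 60000 nM (estimated range 35000 nM to 100000 nM).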

Compound 4, half-maximal inhibitory concentration: > 60000 nM
Compound 4 gave a limit, no number; the forecaster's own chance of this, stated with the estimate: 70%; the middle value sits exactly at the limit.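

In this assay, compound 4 stays at a limit of the assay, just as compound 3 does, so replacing phenyl with cyclopropyl on a carbonyl carbon yields no readable number, and neither the step from compound 3 nor the step from compound 1 can be read. Among the compounds shown here, the only step with a printed size is an at least 1.2-fold higher number from compound 2 to compound 4 (0.08 log units; that floor lies within the scatter), and it does not separate compound 2 from compound 4. What this adds is that two quite different rings on the carbonyl carbon, one aromatic and six-membered and the other non-aromatic and three-membered, both leave the reading at the same limit, and the family now gathers even more tightly there: the limit of > 60000 nM in this assay, at which 3 of the 4 values shown sit.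

Going by these compounds, how compound 3 and compound 4 truly compare remains open, as each is known only through a limit. Also open, on these data alone, is whether an amine, a carboxylic acid or a longer chain on this carbonyl carbon would bring the reading down to an actual number.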